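Isopropyl in place of isobutyl: working notes on the series

The source may hold more compounds than are shown below. What is called first, only, known or untested is meant among the compounds shown, and "the series" means these compounds.

compound 1 `COC[C@H](NC(=O)c1cc(C)on1)C(=O)N[C@@H](CC(C)C)C(=O)N[C@@H](CC(C)C)C(=O)[C@@]1(C)CO1`: 366 nM
compound 2 `Cc1cc(C(=O)N[C@@H](CC(C)C)C(=O)N[C@@H](CCc2ccccc2)C(=O)N[C@@H](CC(C)C)C(=O)[C@@]2(C)CO2)n[nH]1`: > 1000 nM (a limit)

Within the data shown here, in a functional assay on MES-SA cells (Homo sapiens) for cytotoxicity, read by luminescence and CellTiter-Glo, with a stated time of 72 h (on this read-out lower numbers stand for stronger inhibition and higher numbers for weaker inhibition), compound 1 gives the only actual number so far (366 nM). Compound 2 is reported only as a limit (> 1000 nM). The two measured compounds differ in more than one place, so they give no guide to the size of the next step.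

Compound 3 `COC[C@H](NC(=O)c1cc(C)on1)C(=O)N[C@H](C(=O)N[C@@H](CC(C)C)C(=O)[C@@]1(C)CO1)C(C)C` carries isopropyl in place of isobutyl on a saturated chain carbon bound to an amide-type nitrogen and a carbonyl carbon. The change is small, so no step beyond the usual scatter is expected in this assay, with a slight lean towards weaker inhibition. The estimated step is a 1.2-fold higher number from compound 1 to compound 3 (0.09 log units; within the scatter). For compound 3 the expected value is 450 nM, with an estimated range of 150 nM to 1200 nM.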

Compound 3, half-maximal inhibitory concentration: 636 nM
The estimate for compound 3 lay 1.4-fold (0.15 log units) below the measured number; the range from low to high includes it.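

Among these compounds, this gives the first step that can be read at a single place: in this assay, isopropyl in place of isobutyl on a saturated chain carbon bound to an amide-type nitrogen and a carbonyl carbon gives a 1.7-fold higher number from compound 1 to compound 3 (0.24 log units; within the scatter). Isobutyl and isopropyl are therefore not told apart by this read-out at this place, something the earlier pair, which differs in more than one place, could not show. Nothing at hand bears on the cause of this step.

On these data alone, whether a cyclohexyl group, an amine or a carboxylic acid on the same carbon would also stay within the scatter remains open. Also open, as far as these compounds go, is whether the same exchange elsewhere in the shared core would give a similar step.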